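From acetoxy to ((4-methylphenyl)carbonyl)oxy on the shared core

The compounds below may be only part of what the source reports. "The series", "measured", "known", "first", "only" and "open" are said of these compounds alone.

In a functional assay on CaEs17 cells (Homo sapiens) for cytotoxicity, read by MTT assay, with a stated time of 72 h (a lower number here means a stronger inhibitor, a higher number a weaker inhibitor), compound 1 `C=C1C(=O)[C@@]23C(=O)OC[C@]4(C(=O)CCC(C)(C)[C@H]4C=O)[C@@H]2CC[C@@H]1[C@H]3OC(C)=O` gives 1350 nM. Among the compounds with values here, the only comparison available is compound 2 `C=C1C(=O)[C@@]23C(=O)OC[C@]4(C(=O)CCC(C)(C)[C@H]4C=O)[C@@H]2CC[C@@H]1[C@H]3OC(=O)CC`, which gives 1400 nM. Within the data shown here, these two values lie within the scatter of each other, so compound 1 stands level with its one measured neighbour, and the series does not yet show a real spread.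

The open question is compound 3 `C=C1C(=O)[C@@]23C(=O)OC[C@]4(C(=O)CCC(C)(C)[C@H]4C=O)[C@@H]2CC[C@@H]1[C@H]3OC(=O)c1ccc(C)cc1`. The change from compound 1 is 4-methylphenyl in place of methyl on a carbonyl carbon, which turns acetyl into (4-methylphenyl)carbonyl.

Among the measured compounds shown here, one measured step bears on this, a 1.0-fold higher number from compound 1 to compound 2 (0.02 log units; within the scatter), where methyl replaces hydrogen on a saturated chain carbon bound to a carbonyl carbon. For the measured compounds named here, that step is much smaller structurally than the one under consideration, and no measured compound carries an aromatic ring in this place. It is therefore weak evidence, and the range has to stay wide on both sides.

No step beyond the scatter is expected in this assay, and the expected step is a 1.1-fold higher number from compound 1 to compound 3 (0.05 log units; within the scatter). The estimate for compound 3 is 1500 nM, with an expected range of 600 nM to 3500 nM.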

Compound 3, half-maximal inhibitory concentration: 1050 nM
Compound 3: middle estimate off by 1.4-fold (0.15 log units), on the high side; low and high end bracket the measured number.
By their numbers in this assay, from the lowest: compounds 3, 1 and 2 (each within the scatter of the next).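

In this assay, the carbonyl carbon of this ester takes 4-methylphenyl in place of methyl with a 1.3-fold lower number from compound 1 to compound 3 (0.11 log units; within the scatter), and 4-methylphenyl in place of ethyl with a 1.3-fold lower number from compound 2 to compound 3 (0.12 log units; within the scatter). The earlier pair covered only a change from methyl to ethyl, whereas these steps replace a small chain with a group of 7 heavy atoms containing a six-membered aromatic ring, and neither step leaves the scatter. Across acetyl, the propanoyl of compound 2 and (4-methylphenyl)carbonyl, the three compounds therefore stand level, and the readout gives no ranking among them; nothing measured on these compounds offers a reason for this flat result.

The compounds shown leave open whether this level reading extends to groups of another kind on the same carbonyl carbon, such as an amine, a carboxylic acid or a much longer chain. They also leave open whether a free hydroxyl in place of the whole ester would hold the number in this assay, or whether the ester group itself can be changed without a step beyond the scatter.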